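The source may report more compounds than this note shows. Statements on the series, on what has been measured and on what is new or still open speak of the compounds shown alone.

For the measured compounds named here, in an assay on FRT cells for positive allosteric modulation of Cystic fibrosis transmembrane conductance regulator variant N1303K (Homo sapiens), in the presence of a further agent that is not named here (a higher number here means that more compound is needed for the effect, a lower number that less compound is needed), compound 3 (`COc1ccc2[nH]c3c(c2c1)CCNC31CCN(Cc2cc(F)c(F)cc2F)CC1`) gives 600 nM, the lowest of the three numbers so far. Compound 1 (`COc1ccc2[nH]c3c(c2c1)CCNC31CCN(Cc2ccc(Cl)cc2Cl)CC1`) gives 1800 nM in this assay, and compound 2 (`COc1ccc2[nH]c3c(c2c1)CCNC31CCN(Cc2cc(F)ccc2F)CC1`) gives 11100 nM. All three measured steps concern the aryl group on the saturated chain carbon bound to the ring amine nitrogen: a 3.0-fold lower number from compound 1 to compound 3 (0.48 log units; beyond the scatter), a 6.2-fold higher number from compound 1 to compound 2 (0.79 log units; beyond the scatter), and a 19-fold lower number from compound 2 to compound 3 (1.27 log units; beyond the scatter). Compound 4 (`COc1ccc2[nH]c3c(c2c1)CCNC31CCN(Cc2ccco2)CC1`) differs from compound 3 as follows: furan-2-yl in place of 2,4,5-trifluorophenyl on a saturated chain carbon bound to an amine nitrogen in a ring. Going by the values given here, no measured step exchanges the halogenated phenyl for a furan, so the three steps bear on it only indirectly, by showing how much this assay moves with changes at this position, from the modest shift of compound 1 to compound 3 up to the large one from compound 2 to compound 3. Since the 2,4,5-trifluorophenyl that gave compound 3 its low number is lost, a higher number is expected, and compound 4 is estimated at 4000 nM, within 1200 nM to 15000 nM, an expected step of a 6.7-fold higher number from compound 3 to compound 4 (0.82 log units; beyond the scatter).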

Compound 4, half-maximal effective concentration: 16400 nM
Estimate against measurement, compound 4: 4.1-fold (0.61 log units) below; the whole stated range lies below it.
By their numbers in this assay, from the lowest: compound 3; then compound 1; then compounds 2 and 4 (each within the scatter of the next).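

In this assay, the low number of compound 3 does not carry over to furan-2-yl, with a 27-fold higher number from compound 3 to compound 4 (1.44 log units; beyond the scatter), and the 2,4-dichlorophenyl also stands clearly apart from furan-2-yl, with a 9.1-fold higher number from compound 1 to compound 4 (0.96 log units; beyond the scatter). The 2,5-difluorophenyl, however, cannot be told apart from furan-2-yl, with a 1.5-fold higher number from compound 2 to compound 4 (0.17 log units; within the scatter), so among these groups a phenyl ring alone does not give a low number; only its 2,4,5-trifluoro and 2,4-dichloro forms do. No measured evidence accounts for this result.

The compounds shown leave open whether an unsubstituted phenyl, a thiophen-2-yl or a pyridin-2-yl at this place would fall with compound 4 or nearer compound 3. Also open, going by these compounds, is what a longer chain carrying the 2,4,5-trifluorophenyl would give.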